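The compounds below may be only part of what the source reports. "The series", "measured", "known", "first", "only" and "open" are said of these compounds alone.

Working notes on the series, measured in a functional assay on HT-29 cells (Homo sapiens) for inhibition, read by spectrophotometry and sulforhodamine B assay, with a stated time of 48 h; a lower number here means a stronger inhibitor of growth, a higher number a weaker inhibitor of growth:

- compound 1 `S=C(N/N=C/c1c[nH]c2ccc(Br)cc12)Nc1cccc2ccccc12`: 6560 nM
- compound 2 `O=C1CS/C(=N/N=C/c2c[nH]c3ccc(Br)cc23)N1c1cccc2ccccc12`: 27300 nM

Compound 1 holds the lower of the two numbers, and compound 2 lies above it by more than the usual scatter. Compound 3 `S=C(N/N=C/c1c[nH]c2ccccc12)Nc1cccc2ccccc12` is the next to be read against compound 1, from which it differs in one place: hydrogen in place of bromo on an aromatic carbon. Hydrogen stands in place of bromo on an aromatic carbon. Within the data shown here, no measured pair shows this change, so the data do not size it. Only a modest shift in this assay is expected, toward a higher number, and it may stay within the scatter. The expected change is a 1.5-fold higher number from compound 1 to compound 3 (0.18 log units; within the scatter). For compound 3 the estimated value is 10000 nM, with an expected range of 3500 nM to 30000 nM.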

Compound 3, concentration for 50% growth inhibition: 10 nM
For compound 3 the middle estimate is 1000-fold (3.00 log units) above the measured one; measured number outside the range, below it.
By their numbers in this assay, from the lowest: compound 3; then compound 1; then compound 2.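

In this assay, among these compounds, the aromatic carbon meta to a fused ring and para to a fused ring proves highly sensitive: hydrogen in place of bromo gives a 660-fold lower number from compound 1 to compound 3 (2.82 log units; beyond the scatter) and is the first measured step, showing that bromo is not required on the core of compound 1 for growth inhibition. The change removes a single heavy atom and alters no ring, hydrogen-bond donor, hydrogen-bond acceptor or net charge, yet it produces a large step. No evidence in hand explains the size of this step.

Going by these compounds, whether chloro, fluoro, methoxy or an amine on this carbon would give a number closer to compound 3 or to compound 1 remains open. Also open, on these data alone, is whether the same exchange would have a comparable effect on the core of compound 2.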